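Sulfur-bound side chains: from compound 3 to compound 4

The compounds below may be only part of what the source reports. "The series", "measured", "known", "first", "only" and "open" are said of these compounds alone.

Measured in a functional assay on HT-29 cells (Homo sapiens) for inhibition, read by MTT assay, with a stated time of 48 h; a higher number here means a weaker inhibitor, a lower number a stronger inhibitor:
- compound 1 `CCSc1nnc(-c2cc(OC)c(OC)c(OC)c2)n1-c1ccc(N(C)C)cc1`, > 60000 nM (a limit)
- compound 2 `COc1ccc(CSc2nnc(-c3cc(OC)c(OC)c(OC)c3)n2-c2ccc(N(C)C)cc2)cc1`, > 60000 nM (a limit)
- compound 3 `COc1cc(-c2nnc(SCc3ccc(F)cc3)n2-c2ccc(N(C)C)cc2)cc(OC)c1OC`, 44300 nM

For the measured compounds named here, compound 3 gives the only actual number, and the rest of the series stands at the limit of > 60000 nM in this assay, at which 2 of the 3 values shown sit. The step to compound 4 `COc1ccc(C(=O)CSc2nnc(-c3cc(OC)c(OC)c(OC)c3)n2-c2ccc(N(C)C)cc2)cc1` is (4-methoxyphenyl)carbonyl in place of 4-fluorophenyl on a saturated chain carbon bound to a sulfur. Going by the values given here, three measured steps bear on it. One is an at least 1.3-fold lower number from compound 2 to compound 3 (0.13 log units; that floor lies within the scatter), with fluoro in place of methoxy. Another is an at least 1.3-fold lower number from compound 1 to compound 3 (0.13 log units; that floor lies within the scatter). The third is a step that the two limits leave unreadable from compound 1 to compound 2. The first two give only floors within the scatter, so they support no sizeable shift in either direction. The expected change is a 1.2-fold higher number from compound 3 to compound 4 (0.09 log units; within the scatter), none beyond the scatter. The estimate for compound 4 is 55000 nM, with an expected range of 22000 nM to 130000 nM.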

Compound 4, half-maximal inhibitory concentration: 64000 nM
Compound 4: middle estimate off by 1.2-fold (0.07 log units), on the low side; measured number inside the range.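

With (4-methoxyphenyl)carbonyl in place of 4-fluorophenyl on a saturated chain carbon bound to a sulfur, this assay shows a 1.4-fold higher number from compound 3 to compound 4 (0.16 log units; within the scatter). The added carbonyl and the wider group therefore give a second actual number, and it cannot be told apart from the first. The steps from compounds 1 and 2 to compound 4 cannot be read, as both start from a limit: the limit of > 60000 nM in this assay, at which 2 of the 4 values shown sit.

From the compounds shown here alone, it remains open whether any side chain at this place moves the number beyond the scatter. A carboxylic acid or an amine on that chain would test this.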